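Removing the ethoxy group: what a bare phenyl might give

A few compounds are considered here, and "the series" means these few. Any claim that something is new, unique, unknown or untested is made for them only; others in the source may bear on it.

Three compounds share a core in which an aminothiophene carries a trimethoxybenzoyl group and an aryl ring. Compound 1 `COc1cc(C(=O)c2sc(-c3ccc(Cl)c(Cl)c3)cc2N)cc(OC)c1OC` bears a 3,4-dichlorophenyl and in a functional assay on L1210 cells (Mus musculus) for antiproliferative activity (on this read-out lower numbers stand for stronger inhibition and higher numbers for weaker inhibition), compound 1 gives 260 nM. Compound 2 `COc1cc(C(=O)c2sc(-c3cc(OC)c(OC)c(OC)c3)cc2N)cc(OC)c1OC` carries a second trimethoxyphenyl and gives 2300 nM. Compound 3 `CCOc1ccc(-c2cc(N)c(C(=O)c3cc(OC)c(OC)c(OC)c3)s2)cc1` carries a 4-ethoxyphenyl and gives 590 nM, the second highest of the three numbers, between compound 1 and compound 2. For the measured compounds named here, the only single-point step measured, a 2.3-fold higher number from compound 1 to compound 3 (0.36 log units; beyond the scatter), shows that swapping the group on this aryl ring moves the number modestly.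

Compound 4 `COc1cc(C(=O)c2sc(-c3ccccc3)cc2N)cc(OC)c1OC` differs from compound 3 by hydrogen in place of ethoxy on an aromatic carbon. Going by the values given here, no measured step describes removing a substituent from this ring, so the direction cannot be read from the data; the one measured step suggests the change should stay modest. Compound 4 is therefore expected to give 800 nM, within 250 nM to 2500 nM, an estimated step of a 1.4-fold higher number from compound 3 to compound 4 (0.13 log units; within the scatter).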

Compound 4, half-maximal inhibitory concentration: 11 nM
For compound 4 the middle estimate is 73-fold (1.86 log units) above the measured one; measured number outside the range, below it.
By their numbers in this assay, from the lowest: compound 4; then compound 1; then compound 3; then compound 2.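

In this assay, the bare phenyl ring of compound 4 stands far from both substituted rings it can be compared with: hydrogen in place of ethoxy gives a large drop (a 54-fold lower number from compound 3 to compound 4 (1.73 log units; beyond the scatter)), and phenyl in place of 3,4-dichlorophenyl gives another (a 24-fold lower number from compound 1 to compound 4 (1.37 log units; beyond the scatter)). For the compounds shown here, the earlier step between two substituted rings was only modest (a 2.3-fold higher number from compound 1 to compound 3 (0.36 log units; beyond the scatter)), so those compounds gave no sign that this position could move the number so far. Nothing available explains why the unsubstituted ring gives so much lower a number.

As far as these compounds go, it remains open whether a single fluorine or a methyl on this ring would keep the low number or raise it as ethoxy does. From the compounds shown here alone, it is equally open how an amine or a hydroxyl in the place of ethoxy would behave.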